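A few compounds are considered here, and "the series" means these few. Any claim that something is new, unique, unknown or untested is made for them only; others in the source may bear on it.

Among the three compounds measured so far, compound 3 `Cc1c(Cc2ccc(C(C)(C)C)cc2)c(=O)oc2cc(OCC(O)CN3CCC(C(N)=O)CC3)ccc12` is the only one to give a number in an ADME assay on A549 cells (Homo sapiens) for cytotoxicity, read by CellTiter-Glo (on this read-out lower numbers stand for higher toxicity in this test and higher numbers for lower toxicity in this test), where compound 3 gives 14700 nM. Compound 1 `Cc1c(Cc2ccccc2)c(=O)oc2cc(OCC(O)CNc3nc4ccccc4[nH]3)ccc12` reaches only a limit of this assay, > 100000 nM. Compound 2 `Cc1cc(=O)oc2cc(OCC(O)CN3CCC(C(N)=O)CC3)ccc12` likewise stops at a limit, > 100000 nM. Among the compounds with values here, the one step that can be measured in full, an at least 6.8-fold lower number from compound 2 to compound 3 (0.83 log units; beyond the scatter), therefore rests on a limit at one end, and it reads (the limit of > 100000 nM in this assay, at which 2 of the 3 values shown sit).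

Compound 4 `Cc1c(Cc2ccc(F)cc2)c(=O)oc2cc(OCC(O)CN3CCC(C(N)=O)CC3)ccc12` differs from compound 3 in one place: fluoro in place of tert-butyl on an aromatic carbon. The measured step from compound 2 to compound 3 added the entire 4-(tert-butyl)benzyl group, and compound 4 keeps the benzyl while replacing its tert-butyl, so compound 4 sits structurally between compound 2 and compound 3. A part of that step is thus expected to be given back, with the number rising toward the limit seen for compound 2. The step of a 3.4-fold higher number from compound 3 to compound 4 (0.53 log units; beyond the scatter) is the expected size of that return. Compound 4 is expected to give 50000 nM in this assay, within a range from 15000 nM to 150000 nM, with a fair chance that only a limit is reported.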

Compound 4, half-maximal cytotoxic concentration: 89300 nM
Compound 4: the middle estimate sits 1.8-fold (0.25 log units) below what was measured, and the stated range covers the measured number.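

With the benzyl kept, the change from tert-butyl to fluoro on this aromatic carbon gives a 6.1-fold higher number from compound 3 to compound 4 (0.78 log units; beyond the scatter) in this assay. This ties most of the earlier fall in the number to the tert-butyl rather than to the benzyl itself. Against the bare hydrogen, the 4-fluorobenzyl group leaves no clear mark, with an at least 1.1-fold lower number from compound 2 to compound 4 (0.04 log units; that floor lies within the scatter), and this step gives only a floor because one of its ends is a limit: the limit of > 100000 nM in this assay, at which 2 of the 4 values shown sit.

The compounds shown leave open how the number would move with a plain unsubstituted benzyl on this side chain, or with a methoxy, a trifluoromethyl or an isopropyl group in the place of the fluoro. They also leave open whether an amine or a carboxylic acid at that place would keep the number near compound 4 or bring it down toward compound 3.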